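Trimming the Sulfonyl Substituent: Compound 2 to Compound 3

This account rests on a few compounds, and the source may have more. Where it says the series, first, only, none or still open, it means among the compounds named here.

Measured so far in an ADME assay on microsomes from liver (Rattus norvegicus) for metabolic stability; on this read-out higher numbers stand for fast clearance and lower numbers for slow clearance:
compound 1 `COc1cc(-c2nnc(S(=O)(=O)C3CCC3)[nH]2)ccc1-c1cnc(OCC(C)C)c(Cl)c1` gives 61 uL/min
compound 2 `CC(C)COc1ncc(-c2cc(F)c(-c3nnc(S(=O)(=O)NC4CC4)[nH]3)cc2F)cc1Cl` gives 54 uL/min

Going by the values given here, only two compounds have a number in this assay, and they sit close together. Compound 2 has the lower of the two values, but its gap to compound 1 lies within the scatter, so the two cannot be told apart on these data; neither can be called the more stable of the pair.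

Compound 3 `CC(C)COc1ncc(-c2cc(F)c(-c3nnc(S(C)(=O)=O)[nH]3)cc2F)cc1Cl` has not yet been measured. It differs from compound 2 in one place: methyl in place of cyclopropylamino on a sulfonyl sulfur. Among the compounds with values here, nothing among the measured compounds shows what this particular exchange does in this assay, so there is no step to lean on. The two measured compounds, which carry different groups on the sulfonyl sulfur, still land close to one another, which suggests the sulfonyl substituent is not driving large changes here. The step from compound 2 to compound 3 is therefore expected to be small, a 1.1-fold lower number from compound 2 to compound 3 (0.03 log units; within the scatter), not beyond the scatter. Compound 3 is estimated at 50 uL/min, with a range from 25 uL/min to 100 uL/min.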

Compound 3, intrinsic clearance in a liver preparation (reported as CLH), per the amount of preparation that the assay uses: 23 uL/min
Compound 3: the middle estimate sits 2.2-fold (0.34 log units) above what was measured; measured number outside the range, below it.
By their numbers in this assay, from the lowest: compound 3; then compounds 2 and 1 (each within the scatter of the next).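

In this assay, the exchange of cyclopropylamino for methyl on a sulfonyl sulfur gives a 2.3-fold lower number from compound 2 to compound 3 (0.37 log units; beyond the scatter). Going by these compounds alone, this pair differs in that one place alone, so it is the first direct sign that the group on this sulfur can shift the read-out, and the shift here runs towards slow clearance. The step is modest, and the data offer nothing that explains it.

The change takes away several features at once: the three-membered ring, the nitrogen and that nitrogen's hydrogen-bond donor, so this single pair cannot show which of them accounts for the step. As far as these compounds go, a methylamino group or a cyclopropyl group on the same sulfur would separate the nitrogen from the ring, while a longer chain such as ethyl or propyl would show how the number moves as the group grows, and whether the same exchange gives a similar step on the core of compound 1 also remains open.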